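Compound 4: a Methylaminopyrazine in Place of the Pyridine

This account rests on a few compounds, and the source may have more. Where it says the series, first, only, none or still open, it means among the compounds named here.

Compound 2 `CC(C)(C)c1ccc(S(=O)(=O)Nc2ccc(Cl)cc2-c2nccc(C(N)=O)c2O)cc1` gives 52 nM in a functional assay on isolated protein for antagonist activity at C-C chemokine receptor type 9 (Homo sapiens), read by calcium flux, with a stated time of 10 min (a lower number here means a stronger inhibitor, a higher number a weaker inhibitor), the second highest of the three numbers; compound 1 `CC(C)(C)c1ccc(S(=O)(=O)Nc2ccc(Cl)cc2-c2ncccc2CO)cc1` gives 89 nM and compound 3 `CC(C)(C)c1ccc(S(=O)(=O)Nc2ccc(Cl)cc2-c2nc(N)ncc2O)cc1` gives 4 nM. Compound 4 `CNc1nccnc1-c1cc(Cl)ccc1NS(=O)(=O)c1ccc(C(C)(C)C)cc1` differs from compound 2 by a group of 8 heavy atoms (5 carbon, 3 nitrogen; one six-membered aromatic ring with 2 hetero atoms) in place of a group of 10 heavy atoms (6 carbon, 2 nitrogen, 2 oxygen; one six-membered aromatic ring with 1 hetero atom), on an aromatic carbon. Two measured steps change the same position: a 1.7-fold lower number from compound 1 to compound 2 (0.23 log units; within the scatter) and a 13-fold lower number from compound 2 to compound 3 (1.11 log units; beyond the scatter). The second shows that a six-membered aromatic ring with two hetero atoms can bring a large gain, but compound 4 does not carry the same groups as compound 3, so only a moderate gain is expected, with the step estimated as a 1.7-fold lower number from compound 2 to compound 4 (0.24 log units; within the scatter). Compound 4 is therefore expected to give 30 nM, within a range from 8 nM to 120 nM.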

Compound 4, half-maximal inhibitory concentration: 25 nM
Compound 4: the middle estimate sits 1.2-fold (0.08 log units) above what was measured; the range from low to high includes it.
By their numbers in this assay, from the lowest: compound 3; then compound 4; then compounds 2 and 1 (each within the scatter of the next).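

In this assay, the 3-(methylamino)pyrazin-2-yl group shows that this position does not need an oxygen-bearing group, which all three earlier compounds carried: there is a 2.1-fold lower number from compound 2 to compound 4 (0.32 log units; beyond the scatter) and a 3.6-fold lower number from compound 1 to compound 4 (0.55 log units; beyond the scatter). A ring with two hetero atoms does not by itself match compound 3, however, as there is a 6.3-fold higher number from compound 3 to compound 4 (0.80 log units; beyond the scatter). No measurement shown explains these steps. On these data alone, whether a 3-aminopyrazin-2-yl group, with a plain amine instead of the methylamino group, would bring the number closer to that of compound 3 remains open.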